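Removing One Methoxy Group From a Doubly Substituted Core

This account rests on a few compounds, and the source may have more. Where it says the series, first, only, none or still open, it means among the compounds named here.

Compound 1 `COc1ccc2c(/C=C(\C#N)C(=O)c3c[nH]c4cc(OC)ccc34)c[nH]c2c1` carries two methoxy groups on its shared core. In a functional assay on MIA PaCa-2 cells (Homo sapiens) for cytotoxicity, read by WST assay, with a stated time of 24 h (a lower number here means a stronger inhibitor, a higher number a weaker inhibitor), compound 1 is recorded only as a limit, > 50000 nM; this is the limit of > 50000 nM in this assay, at which 1 of the 2 values shown sits, and not a number. Compound 2 `COc1ccc2c(C(=O)/C(C#N)=C/c3c[nH]c4ccccc34)c[nH]c2c1` keeps one methoxy group, and in this assay compound 2 gives 13500 nM. For the measured compounds named here, the single change between these two brings an at least 3.7-fold lower number from compound 1 to compound 2 (0.56 log units; beyond the scatter).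

Compound 3 `COc1ccc2c(/C=C(\C#N)C(=O)c3c[nH]c4ccccc34)c[nH]c2c1` is the other one-methoxy relative of compound 1: hydrogen in place of methoxy on an aromatic carbon. The group that leaves sits on an aromatic carbon of a six-membered aromatic ring of carbon only, part of a fused or bridged system of two rings, meta to a fused ring and para to a fused ring. Going by the values given here, the one measured step that bears on this change is an at least 3.7-fold lower number from compound 1 to compound 2 (0.56 log units; beyond the scatter), and it shows that removing one methoxy group while the other stays brings the number out from the limit by at least a modest amount. A step of similar size and direction is therefore expected for compound 3, that is an at least 3.3-fold lower number from compound 1 to compound 3 (0.52 log units; beyond the scatter). Compound 3 is accordingly estimated at 15000 nM in this assay, with a range from 5000 nM to 50000 nM.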

Compound 3, half-maximal inhibitory concentration: 27500 nM
For compound 3 the middle estimate is 1.8-fold (0.26 log units) below the measured one, and the stated range covers the measured number.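

For the compounds shown here, compound 3 gives the first measured reading for this place, the aromatic carbon meta to a fused ring and para to a fused ring, where the earlier compounds showed only the loss of the other methoxy group. Hydrogen in place of methoxy here also brings the number out from the limit, with an at least 1.8-fold lower number from compound 1 to compound 3 (0.25 log units; that floor lies within the scatter). This step can be stated only as a floor, and the true distance from compound 1 stays unknown, because the value of compound 1 is a limit and not a number: the limit of > 50000 nM in this assay, at which 1 of the 3 values shown sits.

The compounds shown leave open how a hydroxyl group, a fluorine atom, an amine or a longer ethoxy chain in place of this methoxy group would read in this assay, so the result speaks only for the exchange of methoxy for hydrogen. They also leave open how the shared core would read with hydrogen at both methoxy places, and whether the step from compound 1 to compound 3 truly exceeds the usual scatter of this kind of measurement.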